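The compounds below may be only part of what the source reports. "The series", "measured", "known", "first", "only" and "open" are said of these compounds alone.

Of the compounds shown here, two of one series have been measured so far: compound 1 `Cc1ccccc1COc1ccc(N2CCC[C@H]2CC(=O)O)cc1` and compound 2 `Cc1ccccc1Oc1ccc(N2CCC[C@H]2CC(=O)O)cc1`. In a functional assay on cells for agonist activity at Free fatty acid receptor 1 (Homo sapiens), read by FLIPR and calcium flux, with a stated time of 100 s (a lower number here means that less compound is needed, a higher number that more compound is needed for the effect), compound 1 gives 190 nM, and compound 2 gives 74 nM. Within the data shown here, the single step between them, a 2.6-fold lower number from compound 1 to compound 2 (0.41 log units; beyond the scatter), leaves compound 2 with the lowest of the two numbers, its nearest neighbour being compound 1. Compound 3 `O=C(O)C[C@@H]1CCCN1c1ccc(Oc2ccccc2)cc1` has not yet been measured. It differs from compound 2 by hydrogen in place of methyl on an aromatic carbon. Among the measured compounds shown here, the one measured step does not bear on this change: it alters the link between the rings and leaves the methyl in place. For the measured compounds named here, no direct precedent exists for removing the methyl. The expected step in this assay is therefore a 2.0-fold higher number from compound 2 to compound 3 (0.31 log units; beyond the scatter), small and toward a somewhat higher number. Compound 3 is estimated at 150 nM, with a range from 50 nM to 450 nM.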

Compound 3, half-maximal effective concentration: 560 nM
Beside the measured number, compound 3's estimate is 3.7-fold (0.57 log units) below it; measured number above the stated range.
By their numbers in this assay, from the lowest: compound 2; then compound 1; then compound 3.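

The methyl on an aromatic carbon, ortho to a large group, matters in this assay: the change from 2-methylphenyl to phenyl alone gives a clear loss (a 7.6-fold higher number from compound 2 to compound 3 (0.88 log units; beyond the scatter)). Without that methyl, the direct oxygen link no longer gives a lower number than the 2-methylbenzyl group of compound 1 (a 2.9-fold higher number from compound 1 to compound 3 (0.47 log units; beyond the scatter)), so the lower number of compound 2 depends on the methyl being present. No measurement offered here explains the size of this step.

The compounds shown leave open whether an ethyl, a methoxy or a chlorine on the same aromatic carbon would match, improve on or fall short of the methyl. They also leave open what removing the methyl from the 2-methylbenzyl group of compound 1 would do, and so whether the methyl counts equally with the longer link.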